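Small Halogen Swaps and the Bromo Compound

A few compounds are considered here, and "the series" means these few. Any claim that something is new, unique, unknown or untested is made for them only; others in the source may bear on it.

Compound 1 `O=[N+]([O-])c1ccc(-c2nnc(SCCCN3CCN(c4nc5ccccc5o4)CC3)o2)cc1` gives 114000 nM
Compound 2 `Clc1ccc(-c2nnc(SCCCN3CCN(c4nc5ccccc5o4)CC3)o2)cc1` gives 101000 nM
Compound 3 `Fc1ccc(-c2nnc(SCCCN3CCN(c4nc5ccccc5o4)CC3)o2)cc1` gives 196000 nM

All three compounds were tested in a functional assay on HeLa cells (Homo sapiens) for inhibition, read by MTT assay, with a stated time of 72 h (a lower number here means a stronger inhibitor, a higher number a weaker inhibitor), and compound 3, at 196000 nM there, lies within the scatter of both others, so they cannot be put in order. Compound 4 `Brc1ccc(-c2nnc(SCCCN3CCN(c4nc5ccccc5o4)CC3)o2)cc1` has bromo in place of fluoro on an aromatic carbon, para to a large group (bromo in place of fluoro on an aromatic carbon). Going by the values given here, the only measured swap of one halogen for another (a 1.9-fold higher number from compound 2 to compound 3 (0.29 log units; within the scatter)) lies within the scatter. The other two steps (a 1.1-fold lower number from compound 1 to compound 2 (0.05 log units; within the scatter)) and (a 1.7-fold higher number from compound 1 to compound 3 (0.24 log units; within the scatter)) lie within it too. With no large step among these, only a small change is expected in this assay and its direction is uncertain. Taking compound 2 (101000 nM) as the closer model for bromo, an assumption the data cannot test, a slightly lower number is expected. The estimated move (a 1.6-fold lower number from compound 3 to compound 4 (0.21 log units; within the scatter)) would stay within the scatter. For compound 4 the estimated value is 120000 nM with an expected range from 65000 nM to 220000 nM in this test.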

Compound 4, half-maximal inhibitory concentration: 187000 nM
Compound 4: middle estimate off by 1.6-fold (0.19 log units), on the low side; measured number inside the range.
By their numbers in this assay, from the lowest: compounds 2, 1, 4 and 3 (each within the scatter of the next).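

Bromo now joins fluoro, chloro and nitro at this place on the aromatic ring, para to a large group, and in this assay it also stays within the scatter of all three others (a 1.0-fold lower number from compound 3 to compound 4 (0.02 log units; within the scatter)), (a 1.9-fold higher number from compound 2 to compound 4 (0.27 log units; within the scatter)) and (a 1.6-fold higher number from compound 1 to compound 4 (0.21 log units; within the scatter)). The change from 4-fluorophenyl to 4-bromophenyl therefore gives no readable shift, and the four compounds cannot be put in order. No available data explain this flat result.

The compounds shown leave open whether a different kind of group at this place, such as an amine or a carboxylic acid, would give a step beyond the scatter. They also leave open whether a change elsewhere in the molecule, such as a longer chain in place of the one shared here, would do so.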